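Extending the thioether chain from benzyl to phenoxyethyl

The source may hold more compounds than are shown below. What is called first, only, known or untested is meant among the compounds shown, and "the series" means these compounds.

Measured so far:
compound 1 `Cn1c(=O)c2c(nc(Sc3ccccc3)n2C)n(C)c1=O` gives 33200 nM in an assay on isolated protein for inhibition of Amine oxidase [flavin-containing] B (Homo sapiens), read by fluorescence; a lower number here means a stronger inhibitor, a higher number a weaker inhibitor
compound 2 `Cn1c(=O)c2c(nc(SCc3ccccc3)n2C)n(C)c1=O` gives 1860 nM in this assay

Within the data shown here, compound 2 stands lowest of the two numbers, and its only neighbour is compound 1. Compound 3 `Cn1c(=O)c2c(nc(SCCOc3ccccc3)n2C)n(C)c1=O` carries phenoxymethyl in place of phenyl on a saturated chain carbon bound to a sulfur. Among the measured compounds shown here, the one step that bears on this change is an 18-fold lower number from compound 1 to compound 2 (1.25 log units; beyond the scatter), where lengthening the link on the sulfur by one carbon brought a large gain. As far as these compounds go, whether a further lengthening helps again is unknown from these two compounds alone, so only a small step of a 1.2-fold lower number from compound 2 to compound 3 (0.09 log units; within the scatter) is expected. Compound 3 is estimated at 1500 nM, within a range from 400 nM to 6000 nM.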

Compound 3, half-maximal inhibitory concentration: 332 nM
Estimate against measurement, compound 3: 4.5-fold (0.65 log units) above; measured number below the stated range.
By their numbers in this assay, from the lowest: compound 3; then compound 2; then compound 1.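

In this assay, the gain on the sulfur does not stop at benzyl: phenoxymethyl in place of phenyl on a saturated chain carbon bound to a sulfur gives a 5.6-fold lower number from compound 2 to compound 3 (0.75 log units; beyond the scatter), so the position still rewards a longer group. Together with an 18-fold lower number from compound 1 to compound 2 (1.25 log units; beyond the scatter), this makes two lower numbers in a row as the chain grows. Nothing available gives a reason for this gain.

This change adds both length and an oxygen, so their shares cannot be separated. An all-carbon phenylpropyl chain would test the oxygen, and a still longer phenoxypropyl chain would show whether the trend continues.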